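Cytotoxicity notes: from 4-fluorophenyl to 2-methylphenyl

The source may report more compounds than this note shows. Statements on the series, on what has been measured and on what is new or still open speak of the compounds shown alone.

Measured in an ADME assay on Vero 76 cells (Chlorocebus sabaeus) for cytotoxicity, read by MTT assay, with a stated time of 96 h; on this read-out lower numbers stand for higher toxicity in this test and higher numbers for lower toxicity in this test:
- compound 1 `Cc1cccc(C2CC(c3ccc(Oc4ccccc4)cc3)=NN2c2ccc(S(N)(=O)=O)cc2)c1`: 81000 nM
- compound 2 `Cc1ccc(C2CC(c3ccc(Oc4ccccc4)cc3)=NN2c2ccc(S(N)(=O)=O)cc2)cc1`: 86000 nM
- compound 3 `NS(=O)(=O)c1ccc(N2N=C(c3ccc(Oc4ccccc4)cc3)CC2c2ccc(F)cc2)cc1`: 25000 nM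

Compound 3 has the lowest of the three numbers in this assay, at 25000 nM. Compound 4 `Cc1ccccc1C1CC(c2ccc(Oc3ccccc3)cc2)=NN1c1ccc(S(N)(=O)=O)cc1` carries 2-methylphenyl in place of 4-fluorophenyl on a saturated ring carbon. Among the measured compounds shown here, three measured steps bear on this change. The step of a 1.1-fold higher number from compound 1 to compound 2 (0.03 log units; within the scatter) lay within the scatter, so compound 1 and compound 2 read alike. The steps of a 3.2-fold lower number from compound 1 to compound 3 (0.51 log units; beyond the scatter) and a 3.4-fold lower number from compound 2 to compound 3 (0.54 log units; beyond the scatter) were modest and beyond the scatter. For the measured compounds named here, no 2-methylphenyl compound has been measured, so a modest step to a higher number is only an expectation. The expected step is a 2.8-fold higher number from compound 3 to compound 4 (0.45 log units; beyond the scatter). Compound 4 is estimated at 70000 nM, with an expected range from 30000 nM to 130000 nM.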

Compound 4, half-maximal cytotoxic concentration: 90000 nM
The estimate for compound 4 lay 1.3-fold (0.11 log units) below the measured number; the range from low to high includes it.
By their numbers in this assay, from the lowest: compound 3; then compounds 1, 2 and 4 (each within the scatter of the next).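

In this assay the 2-methylphenyl group reads alike with the other two methylphenyl groups on this saturated ring carbon (a 1.1-fold higher number from compound 1 to compound 4 (0.05 log units; within the scatter)) (a 1.0-fold higher number from compound 2 to compound 4 (0.02 log units; within the scatter)), while the change from 4-fluorophenyl is modest and beyond the scatter (a 3.6-fold higher number from compound 3 to compound 4 (0.56 log units; beyond the scatter)). All three methylphenyl compounds now read alike, leaving compound 3 alone at the lower number. No measurement on hand accounts for this difference.

Still open, on these data alone, is how 2-fluorophenyl or 4-chlorophenyl would read here. Also open, as far as these compounds go, is whether an amine or a carboxylic acid on this phenyl ring would shift the number.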